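The compounds below may be only part of what the source reports. "The series", "measured", "known", "first", "only" and "open" are said of these compounds alone.

Measured so far:
compound 1 `CCCCCOC(=O)N1CCN(C(=O)[C@H](CCC(=O)O)NC(=O)c2cc(N3CCC(C(=O)NCC)CC3)nc(-c3ccccc3)n2)CC1` — 0.2 L/kg
compound 2 `CCCCCOC(=O)N1CCN(C(=O)[C@H](CCC(=O)O)NC(=O)c2cc(N3CCC(COC)CC3)nc(-c3ccccc3)n2)CC1` — 1.1 L/kg

In an in vivo ADME assay on the whole organism (strain Sprague-Dawley) for pharmacokinetics, with Rattus norvegicus as the target (a lower number here means that more of the compound stays in the plasma, a higher number that more of the compound sits outside the plasma), compound 2 gives the higher of the two numbers; compound 1 sits below it by a 5.5-fold higher number from compound 1 to compound 2 (0.74 log units; beyond the scatter). Compound 3 `CCCCCOC(=O)N1CCN(C(=O)[C@H](CCC(=O)O)NC(=O)c2cc(N3CCC(C(=O)N4CCCC4)CC3)nc(-c3ccccc3)n2)CC1` differs from compound 2 by (pyrrolidin-1-yl)carbonyl in place of methoxymethyl on a saturated ring carbon. Among the measured compounds shown here, only the step from compound 1 to compound 2 bears on this change, and it was a 5.5-fold higher number from compound 1 to compound 2 (0.74 log units; beyond the scatter). That step moved an amide-bearing ring carbon to an ether-bearing one; here an amide returns, so a move back toward compound 1 is expected, about a 2.8-fold lower number from compound 2 to compound 3 (0.44 log units; beyond the scatter). Compound 3 is therefore estimated at 0.4 L/kg, likely between 0.15 L/kg and 1 L/kg.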

Compound 3, volume of distribution at steady state: 0.2 L/kg
Estimate against measurement, compound 3: 2.0-fold (0.30 log units) above; the measured number falls inside the stated range.
By their numbers in this assay, from the lowest: compounds 1 and 3 (each within the scatter of the next); then compound 2.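

In this assay, a carbonyl group on this saturated ring carbon brings a 5.5-fold lower number from compound 2 to compound 3 (0.74 log units; beyond the scatter) and so cancels the earlier rise. Replacing ethylamino with pyrrolidin-1-yl on that carbonyl carbon gives no change at the digits printed from compound 1 to compound 3 (within the scatter) and shows that these two amides read alike here, while the methoxymethyl group of compound 2 stands apart from both. No measurement at hand explains this difference. On these data alone, whether the match holds for a piperidine or dimethylamino on the carbonyl stays open, as does the outcome with hydroxymethyl or a carboxylic acid on the ring carbon.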